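This account rests on a few compounds, and the source may have more. Where it says the series, first, only, none or still open, it means among the compounds named here.

A set of three compounds was examined in a functional assay on MDA-MB-231 cells (Homo sapiens) for inhibition, read by sulforhodamine B assay, with a stated time of 48 h; a higher number here means a weaker inhibitor of growth, a lower number a stronger inhibitor of growth. Compound 1 `Cc1nnc(-c2nn(-c3ccccc3)c(-c3ccccc3)c2C#N)c2cn(-c3ccccc3)nc12` gives > 100000 nM, which is a limit of the assay and not a number. That limit places compound 1 at the high end of the two readings available so far. Compound 2 `N#Cc1c(-c2nnc(-c3nn(-c4ccccc4)c(-c4ccccc4)c3C#N)c3nn(-c4ccc(Cl)cc4)cc23)nn(-c2ccccc2)c1-c1ccccc1` gives a true number of 7900 nM in this assay.

Compound 3 `N#Cc1c(-c2nnc(-c3ccccc3)c3nn(-c4ccccc4)cc23)nn(-c2ccccc2)c1-c1ccccc1` has not yet been measured. It has phenyl in place of methyl on an aromatic carbon of a six-membered aromatic ring with 2 nitrogen, part of a fused or bridged system of two rings (phenyl in place of methyl on an aromatic carbon). Going by the values given here, no measured pair isolates this change, so any forecast rests on thin evidence. Among the compounds with values here, the one hint comes from compound 2, which also lacks the methyl and reads 7900 nM. A step toward stronger growth inhibition is therefore expected, estimated as an at least 3.3-fold lower number from compound 1 to compound 3 (0.52 log units; beyond the scatter). A reading that is again only a limit remains a real possibility. For compound 3 the expected value is 30000 nM, with an estimated range from 6000 nM to 100000 nM.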

Compound 3, concentration for 50% growth inhibition: 8840 nM
Beside the measured number, compound 3's estimate is 3.4-fold (0.53 log units) above it; the range from low to high includes it.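

Phenyl in place of methyl on this aromatic carbon gives an at least 11-fold lower number from compound 1 to compound 3 (1.05 log units; beyond the scatter) in this assay and turns a reading with no true number into one that has it. Going by these compounds alone, this is the first single change in the set that can be read at all, and it shows that growth inhibition in these cells responds to what sits on this carbon of the six-membered aromatic ring with 2 nitrogen. Going by these compounds, the full size of the step remains unknown because compound 1 stands at a limit of the assay and not at a number: the limit of > 100000 nM in this assay, at which 1 of the 3 values shown sits.

With only this one exchange, the compounds shown cannot tell whether the gain belongs to the phenyl ring itself or would come with any group other than methyl at this carbon. On these data alone, an amine, a methoxy group, a longer chain such as propyl or a phenyl ring carrying a chlorine at this place would separate those readings, and whether the same exchange holds on other versions of the core also stays open.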